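Solubility notes on the chalcone-amide series, compound 4 outlook

This account rests on a few compounds, and the source may have more. Where it says the series, first, only, none or still open, it means among the compounds named here.

Compound 1 `O=C(CN1CCN(c2cc3c(cc2F)c(=O)c(C(=O)O)cn3C2CC2)CC1)Nc1ccc(C(=O)/C=C/c2ccccc2)cc1` gives 2.53 ug/mL in a physicochemical assay for solubility, at pH 7.8; a higher number here means a more soluble compound, a lower number a less soluble compound.
Compound 2 `COc1ccc(/C=C/C(=O)c2ccc(NC(=O)CN3CCN(c4cc5c(cc4F)c(=O)c(C(=O)O)cn5C4CC4)CC3)cc2)cc1` gives 2.42 ug/mL in this assay.
Compound 3 `COc1cc(/C=C/C(=O)c2ccc(NC(=O)CN3CCN(c4cc5c(cc4F)c(=O)c(C(=O)O)cn5C4CC4)CC3)cc2)cc(OC)c1OC` gives 2.01 ug/mL in this assay.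

Compound 2 stands second highest of the measured numbers, with compound 1 nearest and compound 3 furthest, and both neighbours lie within the scatter of it. The step of a 1.0-fold lower number from compound 1 to compound 2 (0.02 log units; within the scatter) and the step of a 1.2-fold lower number from compound 2 to compound 3 (0.08 log units; within the scatter) both fall within the scatter, as does the step of a 1.3-fold lower number from compound 1 to compound 3 (0.10 log units; within the scatter). Across these compounds the aromatic substitution on the double-bonded chain carbon has not moved the read-out beyond noise.

Compound 4 `Cc1ccc(/C=C/C(=O)c2ccc(NC(=O)CN3CCN(c4cc5c(cc4F)c(=O)c(C(=O)O)cn5C4CC4)CC3)cc2)c(C)c1` differs from compound 2 in one place: 2,4-dimethylphenyl in place of 4-methoxyphenyl on a double-bonded chain carbon bound to a double-bonded chain carbon. The measured steps bear on it only loosely, since none of them exchanges the methoxy-bearing ring for a ring carrying only methyl groups. The steps that are known, a 1.0-fold lower number from compound 1 to compound 2 (0.02 log units; within the scatter) and a 1.2-fold lower number from compound 2 to compound 3 (0.08 log units; within the scatter), were both small, so for compound 4 in this assay a step of a 1.2-fold lower number from compound 2 to compound 4 (0.08 log units; within the scatter) is expected, that is, none beyond the scatter. On that basis compound 4 is estimated at 2 ug/mL, with a range from 1 ug/mL to 4 ug/mL.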

Compound 4, solubility: 2.07 ug/mL
The estimate for compound 4 lay 1.0-fold (0.01 log units) below the measured number; measured number inside the range.
By their numbers in this assay, from the lowest: compounds 3, 4, 2 and 1 (each within the scatter of the next).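

Working notes, position on the double-bonded chain carbon: in this assay, the exchange of 4-methoxyphenyl for 2,4-dimethylphenyl gives a 1.2-fold lower number from compound 2 to compound 4 (0.07 log units; within the scatter) and so extends the flat picture to a ring with no oxygen, which the earlier compounds, all phenyl or methoxy-bearing rings, did not cover. The same group set against the other two rings gives a 1.0-fold higher number from compound 3 to compound 4 (0.01 log units; within the scatter) and a 1.2-fold lower number from compound 1 to compound 4 (0.09 log units; within the scatter), so every exchange read at this place, now including methyl substitution, stays within the scatter and no ring shown separates from another in this read-out. No supporting measurement is at hand that could explain this flat result.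

The rings shown carry only hydrogen, methoxy or methyl, so it remains open whether an amine or a carboxylic acid on this ring would give a step beyond the scatter. Compound 4 also carries both methyl groups together, which leaves the step for either methyl group alone unread, and a longer chain in place of the ethenyl link remains an open question as well.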